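The source may report more compounds than this note shows. Statements on the series, on what has been measured and on what is new or still open speak of the compounds shown alone.

Measured compounds:
compound 1 `Cc1nn(C)c(Oc2ccccc2F)c1/C=N\CCCCCCOc1cc2oc(=O)cc(C)c2cc1Cl`: > 25000 nM
compound 2 `Cc1nn(C)c(Oc2ccc(F)c(F)c2)c1/C=N\CCCCCCOc1cc2oc(=O)cc(C)c2cc1Cl`: > 25000 nM

In a functional assay on SMMC-7721 cells (Homo sapiens) for antiproliferative activity, read by MTT assay, with a stated time of 72 h (on this read-out lower numbers stand for stronger inhibition and higher numbers for weaker inhibition), compound 1 gives > 25000 nM, which is a limit of the assay rather than a number. Compound 2 likewise gives > 25000 nM, again a limit. Among the measured compounds shown here, both values sit at the limit of > 25000 nM in this assay, at which 2 of the 2 values shown sit, so the single measured step, a step that the two limits leave unreadable from compound 1 to compound 2, cannot be read for size or direction. Compound 1 therefore stands at the limit, with no resolved figure beside it.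

Compound 3 `Cc1nn(C)c(Oc2ccccc2Br)c1/C=N\CCCCCCOc1cc2oc(=O)cc(C)c2cc1Cl` differs from compound 1 by bromo in place of fluoro on an aromatic carbon. For the measured compounds named here, no measured step touches this change; the only step at hand, from compound 1 to compound 2, is unreadable. With both measured compounds at the limit, compound 3 is expected to remain there as well, with an estimated value of 25000 nM, within a range from 5000 nM to 100000 nM. The expected step is a number no higher from compound 1 to compound 3 (the limit leaves the size open), that is, no change discernible beyond the scatter.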

Compound 3, half-maximal inhibitory concentration: 19700 nM
Compound 3: the middle estimate sits 1.3-fold (0.10 log units) above what was measured; the measured number falls inside the stated range.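

In this assay, the 2-bromophenyl group brings the first number off the limit of the assay at this position, while the two fluorinated compounds stay at that limit: the limit of > 25000 nM in this assay, at which 2 of the 3 values shown sit. Bromo in place of fluoro on an aromatic carbon gives an at least 1.2-fold lower number from compound 1 to compound 3 (0.10 log units; that floor lies within the scatter), and the exchange of the whole aryl group gives an at least 1.2-fold lower number from compound 2 to compound 3 (0.10 log units; that floor lies within the scatter). Both steps are only floors, so the result shows that this position can yield a readable number in this assay, but it does not establish a true gain for bromo over fluoro.

As far as these compounds go, the step between the two compounds at the limit cannot be read, and the true size of both new steps stays unknown. The compounds shown also leave open what chloro, methoxy or an amine on this aromatic carbon would give.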